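Lengthening the hydroxamate linker toward compound 4

This account rests on a few compounds, and the source may have more. Where it says the series, first, only, none or still open, it means among the compounds named here.

For the measured compounds named here, compound 3 `C#CCN(C)Cc1cccc(NC(=O)CCCCCCC(=O)NO)c1` gives 420 nM in a functional assay on DU-145 cells (Homo sapiens) for inhibition, read by MTT assay, with a stated time of 48 h (on this read-out lower numbers stand for stronger inhibition of growth and higher numbers for weaker inhibition of growth), the lowest of the three numbers measured so far; compound 2 `C#CCN(C)Cc1cccc(NC(=O)CCCCCC(=O)NO)c1` gives 4290 nM and compound 1 `C#CCN(C)Cc1cccc(NC(=O)CCCCC(=O)NO)c1` gives 9750 nM. The next compound, compound 4 `C#CCN(C)Cc1cccc(NC(=O)CCCCCCCC(=O)NO)c1`, differs from compound 3 by (hydroxycarbamoyl)methyl in place of hydroxycarbamoyl on a saturated chain carbon, six bonds along the chain from a carbonyl carbon. Two earlier steps of the same kind bear on it: a 2.3-fold lower number from compound 1 to compound 2 (0.36 log units; beyond the scatter) and a 10-fold lower number from compound 2 to compound 3 (1.01 log units; beyond the scatter). Both moved the number downward, the second more strongly than the first, so a further lowering is plausible, but nothing among the three measured compounds shows whether the gain continues at the same size or levels off. The step is therefore expected to be a 1.4-fold lower number from compound 3 to compound 4 (0.15 log units; within the scatter). For compound 4 the estimate is 300 nM, with a range from 100 nM to 1000 nM.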

Compound 4, concentration for 50% growth inhibition: 3780 nM
For compound 4 the middle estimate is 13-fold (1.10 log units) below the measured one; measured number above the stated range.
By their numbers in this assay, from the lowest: compound 3; then compounds 4 and 2 (each within the scatter of the next); then compound 1.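

In this assay, for the compounds shown here, the change from hydroxycarbamoyl to (hydroxycarbamoyl)methyl, six bonds along the chain from a carbonyl carbon, reverses direction, with a 9.0-fold higher number from compound 3 to compound 4 (0.95 log units; beyond the scatter), so the downward run of the earlier steps ends there. The longer chain is not separated from the 2-(hydroxycarbamoyl)ethyl comparison, with a 1.1-fold lower number from compound 2 to compound 4 (0.05 log units; within the scatter), yet a gain over the shortest chain remains, with a 2.6-fold lower number from compound 1 to compound 4 (0.41 log units; beyond the scatter). The outcome of lengthening thus depends on the chain it starts from: the same change on two cores in this assay, a 2.3-fold lower number (0.36 log units; beyond the scatter) from compound 1 to compound 2 and a 9.0-fold higher number (0.95 log units; beyond the scatter) from compound 3 to compound 4, 20-fold (1.31 log units) apart, beyond the scatter of two such steps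

The compounds shown leave open whether a still longer chain raises the number further, and whether a carboxylic acid in place of the hydroxycarbamoyl keeps any growth inhibition.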